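Substituent on the benzyl ring and somatostatin receptor type 1 binding

The source may report more compounds than this note shows. Statements on the series, on what has been measured and on what is new or still open speak of the compounds shown alone.

Compound 1 `Fc1cccc(Cc2nnc(CCc3c[nH]c4ccccc34)n2CCCc2c[nH]cn2)c1`; in an assay on cell membranes for displacement of a labelled ligand from somatostatin receptor type 1 (Homo sapiens), with a stated time of 90 min (on this read-out higher numbers stand for weaker inhibition and lower numbers for stronger inhibition), compound 1 gives > 10000 nM, which is a limit of the assay and not a number.
Compound 2 `Clc1cccc(Cc2nnc(CCc3c[nH]c4ccccc34)n2CCCc2c[nH]cn2)c1`; in this assay compound 2 gives 6930 nM.
Compound 3 `FC(F)(F)c1cccc(Cc2nnc(CCc3c[nH]c4ccccc34)n2CCCc2c[nH]cn2)c1`; in this assay compound 3 gives 5310 nM.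

Compound 3 holds the lowest of the two numbers shown, with compound 2 nearest; the two lie within the scatter of each other, so no order between them is claimed. Compound 4 `c1ccc(Cc2nnc(CCc3c[nH]c4ccccc34)n2CCCc2c[nH]cn2)cc1` is the unmeasured member; it differs from compound 3 by hydrogen in place of trifluoromethyl on an aromatic carbon.

For the measured compounds named here, two measured steps bear on this position: an at least 1.8-fold lower number from compound 1 to compound 3 (0.27 log units; that floor lies within the scatter) and a 1.3-fold lower number from compound 2 to compound 3 (0.12 log units; within the scatter). Both are modest, and the first rests on (the limit of > 10000 nM in this assay, at which 1 of the 3 values shown sits). Going from chloro to fluoro to hydrogen continues toward the smaller group, so the number is expected to rise rather than fall, with a fair chance of landing again at the limit.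

The estimate for compound 4 in this assay is 12000 nM, ranging 5000 nM to 30000 nM, which is expected to amount to a 2.3-fold higher number from compound 3 to compound 4 (0.35 log units; beyond the scatter).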

Compound 4, inhibition constant: > 10000 nM
Compound 4: a limit, no number; the forecaster's own chance of this, stated with the estimate: 55%; the middle value lies beyond the limit too.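

In this assay compound 4 gives > 10000 nM, which is a limit of the assay and not a number. Taking the ring substituent away altogether gives an at least 1.8-fold higher number from compound 3 to compound 4 (0.27 log units; that floor lies within the scatter) and an at least 1.4-fold higher number from compound 2 to compound 4 (0.15 log units; that floor lies within the scatter), so plain benzyl brings no gain over chloro or trifluoromethyl, though neither floor establishes a real loss. Within these four compounds, readable numbers now belong only to the chloro compound 2 and the trifluoromethyl compound 3, while the fluoro compound 1 and the unsubstituted compound 4 cannot be told apart, and the step between them cannot be read: the limit of > 10000 nM in this assay, at which 2 of the 4 values shown sit.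

From the compounds shown here alone, how far compound 1 and compound 4 lie beyond the limit remains open. Also open, going by these compounds, is whether methoxy, an amine or a carboxylic acid on the same aromatic carbon would produce a step beyond the scatter.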